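Furan to pyrazole on the amide side chain of compound 2

The source may hold more compounds than are shown below. What is called first, only, known or untested is meant among the compounds shown, and "the series" means these compounds.

Three compounds were tested in an assay on HEK293 cells for agonist activity at transient receptor potential cation channel subfamily M member 8 (Homo sapiens), read by fluorescence and calcium flux, with a stated time of 15 min; a higher number here means that more compound is needed for the effect, a lower number that less compound is needed. Compound 1 `CCN(Cc1cccs1)C(=O)c1cc2cc(C)ccc2o1` gives 120 nM in this assay. Compound 3 `Cc1ccc(OCC(=O)N(Cc2cccs2)c2ccon2)cc1` gives 2 nM in this assay. Compound 2 `CCN(Cc1ccco1)C(=O)COc1ccc(C)cc1` gives 489 nM in this assay, the highest number of the three, with compound 1 nearest and compound 3 furthest. Among the compounds with values here, compound 2 shares with the others only parts of its build, and no single-point step joins it to either, so the gaps to compounds 1 and 3 are taken as they stand.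

The account turns to compound 4 `CCN(Cc1cc[nH]n1)C(=O)COc1ccc(C)cc1`, which has not been measured in this assay. It differs from compound 2 in one place: 1H-pyrazol-3-yl in place of furan-2-yl on a saturated chain carbon bound to an amide-type nitrogen. Within the data shown here, no measured pair shows this change, so the direction rests on no direct comparison. Compound 4 is expected to give 700 nM in this assay, with a range from 200 nM to 2500 nM. The step is expected to come out as a 1.4-fold higher number from compound 2 to compound 4 (0.16 log units; within the scatter), a small move that may not exceed the usual scatter.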

Compound 4, half-maximal effective concentration: "not active" (no number reported)
Compound 4 has no reported number here, so the estimate cannot be set against anything.
By their numbers in this assay, from the lowest: compound 3; then compound 1; then compound 2.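

Within the data shown here, compound 4 is reported as not active in this assay, without a number, so no step from compound 2 to compound 4 can be read. No other data here bear on this result. The compounds shown leave open how large the effect of replacing furan-2-yl with 1H-pyrazol-3-yl is.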